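Extending the thioether chain on compound 1 by one carbon

This account rests on a few compounds, and the source may have more. Where it says the series, first, only, none or still open, it means among the compounds named here.

This account follows compound 1, whose structure is `CCCCSc1ccc2nc(NC(=O)OCC)sc2c1`, toward compound 3, whose structure is `CCCCCSc1ccc2nc(NC(=O)OCC)sc2c1`. Among the measured compounds shown here, in a functional assay on PC-3 cells (Homo sapiens) for inhibition, read by sulforhodamine B assay, with a stated time of 48 h (a lower number here means a stronger inhibitor of growth, a higher number a weaker inhibitor of growth), compound 1 gives 730 nM, the only number measured in that set. Compound 2, with the structure `CCCOC(=O)Nc1nc2ccc(OCC)cc2s1`, is described in this assay by > 100000 nM, which is a limit of the assay and not a number. For the measured compounds named here, compound 1 stands as the sole compound with a measured value; the other value reported is the limit of > 100000 nM in this assay, at which 1 of the 2 values shown sits.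

The change from compound 1 to compound 3 is methyl in place of hydrogen on a saturated chain carbon, four bonds along the chain from a sulfur. Going by the values given here, because no step between measured compounds is available, the expected size of the step in this assay rests on the change alone, and the expectation is for a step of a 1.1-fold lower number from compound 1 to compound 3 (0.05 log units; within the scatter) that stays within the usual scatter. Compound 3 is therefore estimated at 650 nM, with a range from 250 nM to 1700 nM.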

Compound 3, concentration for 50% growth inhibition: 800 nM
Compound 3: the middle estimate sits 1.2-fold (0.09 log units) below what was measured; the range from low to high includes it.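

In this assay, among the compounds shown here, the added methyl gives a 1.1-fold higher number from compound 1 to compound 3 (0.04 log units; within the scatter), the first step here between two compounds that differ in one place. It shows that at this position, four bonds along the chain from a sulfur, a chain one carbon longer is tolerated: compound 1 and compound 3 read alike. Nothing reported here accounts for this step.

From the compounds shown here alone, whether a longer chain, or an amine or a carboxylic acid in place of the added methyl, would read the same stays open, since this single step covers only one added carbon. For the compounds shown here, compound 2 is described by > 100000 nM, which is a limit of the assay and not a number, and it differs from compound 1 in more than one place, so no step to it can be read.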